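Compound 3 to compound 4: a benzyl group replaces an aryl group

The source may hold more compounds than are shown below. What is called first, only, known or untested is meant among the compounds shown, and "the series" means these compounds.

In a functional assay on HepG2 cells (Homo sapiens) for antiproliferative activity, read by MTT assay (a higher number here means a weaker inhibitor, a lower number a stronger inhibitor), compound 2 `CCc1ccccc1-n1cc(COc2ccc(/C=C/C(=O)c3cc4c(cc3O)OC(C)(C)CC4)cc2)nn1` gives 115000 nM and compound 3 `Cc1ccc(-n2cc(COc3ccc(/C=C/C(=O)c4cc5c(cc4O)OC(C)(C)CC5)cc3)nn2)cc1Br` gives 117000 nM on the shared core. These two numbers lie within the scatter of each other, so compound 3 stands level with compound 2. Compound 1 `COc1ccc(-n2cc(COc3ccc(/C=C/C(=O)c4cc5c(cc4O)OC(C)(C)CC5)cc3)nn2)c([N+](=O)[O-])c1`, which also holds a nitro group, is reported as "not active" (no number reported) with no number given, and a report of that kind is expected to stay possible for compound 4.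

Among the measured compounds shown here, the one measured step is a 1.0-fold higher number from compound 2 to compound 3 (0.01 log units; within the scatter) and it exchanges one substituted phenyl group for another. Compound 4 `CC1(C)CCc2cc(C(=O)/C=C/c3ccc(OCc4cn(Cc5ccc([N+](=O)[O-])cc5)nn4)cc3)c(O)cc2O1` carries 4-nitrobenzyl in place of 3-bromo-4-methylphenyl on an aromatic nitrogen of a five-membered aromatic ring with 3 nitrogen, the change being 4-nitrobenzyl in place of 3-bromo-4-methylphenyl on an aromatic nitrogen with the shared core untouched.

For the measured compounds named here, no measured compound carries a benzyl group, so the measured step bears on this change only loosely. No shift beyond the scatter is expected in this assay and no firm direction can be given. The estimated step is a 1.2-fold lower number from compound 3 to compound 4 (0.07 log units; within the scatter) with wide uncertainty around it. For compound 4 the estimate is 100000 nM with expected ends at 30000 nM and 250000 nM in this series.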

Compound 4, half-maximal inhibitory concentration: 109000 nM
Estimate against measurement, compound 4: 1.1-fold (0.04 log units) below; low and high end bracket the measured number.
By their numbers in this assay, from the lowest: compounds 4, 2 and 3 (each within the scatter of the next).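

Working notes on the nitrogen substituent. In this assay, moving from a directly attached aryl group to a benzyl group on the aromatic nitrogen gives a 1.1-fold lower number from compound 3 to compound 4 (0.03 log units; within the scatter), and the comparison with the other aryl example gives a 1.1-fold lower number from compound 2 to compound 4 (0.02 log units; within the scatter). All three numeric compounds therefore stand level, and this level now also covers 4-nitrobenzyl, with 10 heavy atoms and 2 hydrogen-bond acceptors, against 3-bromo-4-methylphenyl, with 8 heavy atoms and no hydrogen-bond acceptors. Among the compounds shown here, a nitro group occurs in compound 1, reported as "not active" (no number reported), and also in compound 4, which gives 109000 nM, so a nitro group does not always go with a report lacking a number, although no step to compound 1 can be read. Nothing available accounts for this flat result.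

The compounds shown leave open whether a benzyl group bearing an amine or a carboxylic acid in place of the nitro group would leave this level in this assay. They also leave open whether a longer chain in place of the single carbon of the benzyl group would produce a step beyond the scatter.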